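The compounds below may be only part of what the source reports. "The series", "measured", "known", "first", "only" and "open" are said of these compounds alone.

compound 1 `Cc1ccc(C(=O)Nc2cccc(-c3ccnc4c(N)cccc34)c2)cc1C` — > 20000 nM
compound 2 `Cc1cc(C(=O)Nc2cccc(-c3ccnc4c(N)cccc34)c2)ccc1Br` — 9900 nM
compound 3 `CC(=O)Nc1cccc2c(-c3cccc(NC(=O)c4ccc(Br)c(C)c4)c3)ccnc12` — > 20000 nM

All values come from a functional assay on A375P cells (Homo sapiens) for antiproliferative activity, read by MTT assay, with a stated time of 48 h; a lower number here means a stronger inhibitor, a higher number a weaker inhibitor. For compound 1 the value is a limit of the assay, not a number. For compound 3 the value is likewise a limit, as recorded in the limit of > 20000 nM in this assay, at which 2 of the 3 values shown sit. Compound 2 alone gives a number. The steps of an at least 2.0-fold lower number from compound 1 to compound 2 (0.30 log units; that floor lies within the scatter) and an at least 2.0-fold higher number from compound 2 to compound 3 (0.30 log units; that floor lies within the scatter) each rest on a limit and neither exceeds the scatter, so compound 3 stands at the assay limit without a number. Compound 4 `CC(=O)Nc1cccc2c(-c3cccc(NC(=O)c4ccc5c(c4)OCCO5)c3)ccnc12` differs from compound 3 by 2,3-dihydro-1,4-benzodioxin-6-yl in place of 4-bromo-3-methylphenyl on a carbonyl carbon. Going by the values given here, no measured step exchanges the group on the carbonyl carbon; the two existing steps alter a ring substituent and a nitrogen on an aromatic ring, both within the scatter. No shift beyond the scatter is therefore expected in this assay. The expected step is a step that the limit leaves unreadable from compound 3 to compound 4. Compound 4 is estimated at 25000 nM, from 8000 nM to 60000 nM.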

Compound 4, half-maximal inhibitory concentration: 570 nM
Estimate against measurement, compound 4: 44-fold (1.64 log units) above; measured number outside the range, below it.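

In this assay, going by these compounds alone, the group on the carbonyl carbon is the first place where a change moves the read-out beyond the scatter, with the acetyl on the nitrogen kept: an at least 35-fold lower number from compound 3 to compound 4 (1.54 log units; beyond the scatter). The earlier steps shown here, at a ring substituent and at the nitrogen, both stayed within the scatter. The size of the new step is only a floor, because compound 3 stands at a limit: the limit of > 20000 nM in this assay, at which 2 of the 4 values shown sit.

As far as these compounds go, whether the effect belongs to the ring oxygens or to the whole 2,3-dihydro-1,4-benzodioxin-6-yl group stays open, and a 3,4-dimethoxyphenyl group on this carbonyl carbon would bear on that. Also open, from the compounds shown here alone, is whether the effect holds with the acetyl absent from the nitrogen.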